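The source may hold more compounds than are shown below. What is called first, only, known or untested is meant among the compounds shown, and "the series" means these compounds.

Measured so far in this series:
- compound 1 `Cc1ccc(N2C(=O)COc3ccc(-c4cnc5ccccc5c4)cc32)cc1`: > 40000 nM
- compound 2 `O=C1COc2ccc(-c3cnc4ccccc4c3)cc2N1c1ccc(F)cc1`: > 40000 nM
- compound 3 `Cc1ccc(N2C(=O)COc3ccc(-c4cccc(NS(=O)(=O)c5ccc(F)cc5)c4)cc32)cc1`: 35600 nM

In a functional assay on HCT-116 cells (Homo sapiens) for antiproliferative activity, read by MTT assay, with a stated time of 72 h (on this read-out higher numbers stand for weaker inhibition and lower numbers for stronger inhibition), compound 1 reaches only a limit, > 40000 nM. Compound 2 likewise reaches only a limit, > 40000 nM. The change fluoro in place of methyl on an aromatic carbon therefore gives a step that the two limits leave unreadable from compound 1 to compound 2 because both values sit at the limit of > 40000 nM in this assay, at which 2 of the 3 values shown sit. Within the data shown here, compound 3 is the only compound with a number in this assay, 35600 nM; how its core differs from the core of compound 1 is not broken down here.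

Compound 4 `O=C1COc2ccc(-c3cccc(NS(=O)(=O)c4ccc(F)cc4)c3)cc2N1c1ccc(F)cc1` carries the same change on the core of compound 3, (fluoro in place of methyl on an aromatic carbon), with the place described in the same words as before. In this assay the step from compound 3 to compound 4 is expected to be a 1.1-fold higher number from compound 3 to compound 4 (0.05 log units; within the scatter), set beside the unreadable a step that the two limits leave unreadable from compound 1 to compound 2; this rests on compound 3 giving 35600 nM and on the earlier step giving no readable size. Compound 4 is estimated at 40000 nM, expected between 15000 nM and 100000 nM, with a fair chance of only a limit.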

Compound 4, half-maximal inhibitory concentration: > 40000 nM
Compound 4: only a limit was reported; the forecaster's own chance of this, stated with the estimate: 50%; the middle value sits exactly at the limit.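

In this assay, fluoro in place of methyl gives an at least 1.1-fold higher number from compound 3 to compound 4 (0.05 log units; that floor lies within the scatter). Compound 4 reaches only a limit, > 40000 nM, so this step gives a floor and no true size, and it does not show that the change has a real effect on this core. The step on the other core cannot be read, leaving no two sizes to compare, so carrying the change from one core to another cannot be judged, because most of the values sit at one limit: the limit of > 40000 nM in this assay, at which 3 of the 4 values shown sit.

Going by these compounds, it remains open how an amine or a carboxylic acid in place of the methyl of the 4-methylphenyl group would read in this assay. Also open, on these data alone, is whether any change on these cores gives a number well clear of the limit.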